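The compounds below may be only part of what the source reports. "The series", "measured", "known", "first", "only" and "open" are said of these compounds alone.

Compound 1 `COC(=O)c1ccc(NC(=O)Nc2cc(C)nc3ccccc23)cc1`: 21000 nM
Compound 2 `COc1ccc(NC(=O)Nc2cc(C)nc3ccccc23)cc1F`: 26000 nM
Compound 3 `Cc1cc(NC(=O)Nc2cc(Cl)cc(Cl)c2)c2ccccc2n1`: > 25000 nM

In an ADME assay on BJ cells (Homo sapiens) for cytotoxicity, with a stated time of 72 h (a higher number here means that more compound is needed for the effect, a lower number that less compound is needed), compound 1 gives 21000 nM and compound 2 gives 26000 nM, two numbers within the usual scatter of each other. For the measured compounds named here, these are the only two true numbers so far, so compound 1 stands level with compound 2. Compound 3 gives > 25000 nM, which is a limit of the assay and not a number.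

The next compound to consider is compound 4 `Cc1cc(NC(=O)Nc2ccc(C(=O)O)cc2)c2ccccc2n1`. It differs from compound 1 in one place, with hydrogen in place of methyl on an oxygen next to a carbonyl group. The same difference can be read as methoxycarbonyl to carboxy.

Going by the values given here, no measured pair shows this change, so any expectation for it is uncertain. The measured compounds do not spread widely in this assay, which argues against a large move. A small step towards a higher number seems the most reasonable expectation, and it may not clear the usual scatter. The expected change is a 1.4-fold higher number from compound 1 to compound 4 (0.15 log units; within the scatter). A limit instead of a number is also a real possibility. For compound 4 the estimated value is 30000 nM, with an expected range from 15000 nM to 60000 nM.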

Compound 4, half-maximal effective concentration: > 25000 nM
Compound 4: no number, only a limit (the forecaster's own chance of this, stated with the estimate: 45%); the middle value does not contradict the limit.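

For the compounds shown here, replacing methoxycarbonyl with carboxy gives the first view of a change at this place in this assay, and compound 4 returns a limit of the assay, > 25000 nM, rather than a number. Going by these compounds, as a step, this can be read only as a floor, an at least 1.1-fold higher number from compound 1 to compound 4 (0.07 log units; that floor lies within the scatter), so the true size of the change stays unknown and may be small or large. Putting hydrogen in place of methyl on this oxygen gives no sign of a lower number, and the result joins a limit already seen in this small set: the limit of > 25000 nM in this assay, at which 2 of the 4 values shown sit.

Where the true value of compound 4 lies remains open, as does whether the same change would give a readable step on a compound whose starting value sits further from the limit. Also open, on these data alone, is what an amine, an amide or a longer chain in place of the methoxycarbonyl group of compound 1 would do in this assay, since a single change at this place cannot show a trend.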